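The source may hold more compounds than are shown below. What is called first, only, known or untested is meant among the compounds shown, and "the series" means these compounds.

Measured so far:
Compound 1, `C[C@@H]1C[C@H]2C(=O)C(C)(C)[C@H](O)CC[C@]2(O)[C@@]1(C)CCC1=CC(=O)OC1`: > 10000 nM
Compound 2, `C[C@@H]1CC[C@@]2(O)[C@@H](C[C@@H](O)C2(C)C)C(=O)[C@@]1(C)CCC1=CC(=O)OC1`: > 10000 nM

In a functional assay on HEp-2 cells (Homo sapiens) for cytotoxicity, read by MTT assay, with a stated time of 3 days (a lower number here means a stronger inhibitor, a higher number a weaker inhibitor), compound 1 returns only a limit, > 10000 nM. In this assay compound 2 likewise returns only a limit, > 10000 nM. For the measured compounds named here, compound 2 therefore stands nowhere on a numeric scale: its result is a limit, and the one other value shown is a limit as well, so no measured step between them can be sized.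

The account follows compound 2 to compound 3, `C[C@@H]1CC[C@]2(O)[C@H](C[C@@H](O)C2(C)C)C(=O)[C@@]1(C)CCC1=CC(=O)OC1`. The change is the two compounds have the same atoms and bonds and differ only in configuration as drawn: 2 of 5 stereo elements differ; a stereocentre at a saturated ring carbon is drawn R in compound 2 and S in compound 3; a stereocentre at a saturated ring carbon is drawn R in compound 2 and S in compound 3. No measured step among the shown compounds exists to guide the size of this one. Because both shown results sit at the limit of > 10000 nM in this assay, at which 2 of the 2 values shown sit, the expectation for compound 3 is no step beyond the scatter, in either direction, and most likely another limit rather than a number.

Compound 3 is expected to give 15000 nM, with a range from 4000 nM to 60000 nM. The estimated step is a step that the limit leaves unreadable from compound 2 to compound 3.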

Compound 3, half-maximal inhibitory concentration: > 10000 nM
Compound 3 ended at the assay's limit; the forecaster's own chance of this, stated with the estimate: 80%; the middle value lies beyond the limit too.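

Compound 2 and compound 3 each return only a limit in this assay, so no step can be read between them. The compounds shown leave open whether a change in configuration as drawn alters cytotoxicity, as none of them gives a numeric value.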